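The source may report more compounds than this note shows. Statements on the series, on what has been measured and on what is new or still open speak of the compounds shown alone.

Measured compounds:
- compound 1, `CCc1ccc(NC2=CC(=O)c3nc4n(c3C2=O)[C@H]2OC[C@@H](O)[C@H]2OC4)cc1`, a functional assay on MGC-803 cells (Homo sapiens) for inhibition, read by sulforhodamine B assay; on this read-out lower numbers stand for stronger inhibition and higher numbers for weaker inhibition: 1290 nM
- compound 2, `CCOc1ccccc1NC1=CC(=O)c2c(nc3n2[C@H]2OC[C@@H](O)[C@H]2OC3)C1=O`, this assay: 2830 nM

Compound 1 stands at the lowest of the two numbers in this assay. Compound 2 gives the higher number of the two, and the gap between them lies beyond the usual scatter. Among the measured compounds shown here, the two measured compounds differ in more than one place, so no single step links them, and no measured step gives a direct guide to what follows.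

Compound 3, `COc1cccc(NC2=CC(=O)c3nc4n(c3C2=O)[C@H]2OC[C@@H](O)[C@H]2OC4)c1`, is not yet measured in this assay. It differs from compound 1 in one place: 3-methoxyphenyl in place of 4-ethylphenyl on an amine nitrogen. For the measured compounds named here, no measured compound carries a group of this kind, so nothing among the numbers so far shows what this exchange does. The expected step from compound 1 to compound 3 is a 1.4-fold higher number from compound 1 to compound 3 (0.14 log units; within the scatter), a small shift towards a higher number, of a size that may not rise above the scatter. On that basis compound 3 is estimated to give about 1800 nM in this assay, with a range from 600 nM to 5400 nM.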

Compound 3, half-maximal inhibitory concentration: 1780 nM
Compound 3: the middle estimate sits 1.0-fold (0.00 log units) above what was measured, and the stated range covers the measured number.
By their numbers in this assay, from the lowest: compounds 1, 3 and 2 (each within the scatter of the next, the first and the last beyond it).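

In this assay, among the compounds shown here, 3-methoxyphenyl in place of 4-ethylphenyl on the amine nitrogen gives a 1.4-fold higher number from compound 1 to compound 3 (0.14 log units; within the scatter), the first step at this position that can be read from a change in one place. On this read-out, the numbers do not separate the two groups, even though the entering group brings an oxygen and a hydrogen-bond acceptor that the leaving group lacks. Nothing available on these compounds speaks to the reason for this result.

This single step swaps ethyl for methoxy and also moves the group from the 4 to the 3 location named on the phenyl ring, so the effects of the two changes cannot be told apart; 4-methoxyphenyl or 3-ethylphenyl would be needed to separate them. On these data alone, it also remains open whether the tolerance seen here extends beyond these substituted phenyl rings, for example to a phenyl ring carrying a carboxylic acid or a basic amine, or to a plain alkyl chain on the amine nitrogen.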